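Methyl for Methoxy on the Benzamide of Compound 3

A few compounds are considered here, and "the series" means these few. Any claim that something is new, unique, unknown or untested is made for them only; others in the source may bear on it.

Compound 1 `O=C(Nc1nc2ccc([N+](=O)[O-])cc2s1)c1ccc(C(F)(F)F)cc1` gives 1.65 ug/mL in a functional assay on NUGC-3 cells (Homo sapiens) for antiproliferative activity, read by sulforhodamine B assay; on this read-out higher numbers stand for weaker inhibition of growth and lower numbers for stronger inhibition of growth. Compound 2 `COc1cccc2sc(NC(=O)c3ccc(C(F)(F)F)cc3)nc12` reaches only the assay limit, > 10 ug/mL. Compound 3 `COc1ccc(C(=O)Nc2nc3cc(C)cc(C)c3s2)cc1` likewise stops at the limit of > 10 ug/mL in this assay, so it has no number of its own. Compound 3 thus sits at the limit of > 10 ug/mL in this assay, at which 2 of the 3 values shown sit, while only compound 1 gives a real value. Compound 4 `Cc1ccc(C(=O)Nc2nc3cc(C)cc(C)c3s2)cc1` differs from compound 3 by methyl in place of methoxy on an aromatic carbon. Within the data shown here, no measured step covers this change, and the two limits give no direction. The expected step is a number no higher from compound 3 to compound 4 (the limit leaves the size open), none beyond the scatter in this assay. Compound 4 is therefore estimated at 10 ug/mL, between 3 ug/mL and 30 ug/mL, most likely reported again as a limit.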

Compound 4, concentration for 50% growth inhibition: 2.37 ug/mL
Compound 4: the middle estimate sits 4.2-fold (0.63 log units) above what was measured, and the stated range ends above it.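

In this assay, methyl in place of methoxy on the aromatic carbon para to a large group gives an at least 4.2-fold lower number from compound 3 to compound 4 (0.62 log units; beyond the scatter). Among these compounds, this is the first measured step, and it shows that this position responds to the group it carries while the shared core stays the same. Compound 3 has only a limit, so the step fixes a minimum size and no exact one: the limit of > 10 ug/mL in this assay, at which 2 of the 4 values shown sit.

From the compounds shown here alone, how an amine, a chlorine atom or a longer chain would read at this position remains open. Going by these compounds, whether the same change holds on the cores of compound 1 and compound 2 also remains open.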